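Chloro removal on the sulfonyl ring of compound 2

A few compounds are considered here, and "the series" means these few. Any claim that something is new, unique, unknown or untested is made for them only; others in the source may bear on it.

Two compounds of this series have numbers in an assay on isolated protein for displacement of a labelled ligand from metabotropic glutamate receptor 5 (Homo sapiens), with a stated time of 60 min, tested at 1 uM (on this read-out higher numbers stand for more inhibition at the one concentration tested (going by the name of the read-out) and lower numbers for less inhibition), so far. Compound 1, `CC1CCN(c2c(S(=O)(=O)c3ccccc3)cnc3ccccc23)CC1`, gives 89.2% in this assay. Compound 2, `CC1CCN(c2c(S(=O)(=O)c3cccc(Cl)c3)cnc3cc(Cl)ccc23)CC1`, gives 92% in this assay, which is the highest of the two numbers shown; its nearest neighbour is compound 1, and the gap between the two lies within the scatter, so the two read as equal.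

Compound 3, `CC1CCN(c2c(S(=O)(=O)c3ccccc3)cnc3cc(Cl)ccc23)CC1`, has not been measured in this assay. It differs from compound 2 in one place: hydrogen in place of chloro on an aromatic carbon. The change sits, in the terms computed from the two structures, on an aromatic carbon of a six-membered aromatic ring of carbon only, meta to a large group.

Within the data shown here, no step between measured compounds is available for this change. Since compound 1 and compound 2 already read alike in this assay despite both differing by chloro groups, the expected step in this assay from compound 2 to compound 3 is a number 2 percentage points lower from compound 2 to compound 3 (within the scatter), that is none beyond the scatter. For compound 3 the expected value in this assay is 90%, with a range from 80% to 96%.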

Compound 3, a percentage reported as inhibition, at one concentration (the size of the read-out at that concentration, not a potency): 93%
Estimate against measurement, compound 3: 3 percentage points below; the measured number falls inside the stated range.
By their numbers in this assay, from the lowest: compounds 1, 2 and 3 (each within the scatter of the next).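

The step from 3-chlorophenyl to phenyl reads a number 1 percentage points higher from compound 2 to compound 3 (within the scatter) in this assay and so the chloro on this aromatic carbon, meta to a large group, can be replaced by hydrogen without a step beyond the scatter. The other chloro, read as a single change, gives a number 3.8 percentage points higher from compound 1 to compound 3 (within the scatter) and so also stays inside the scatter, which leaves compound 3 reading alike with both compound 1 and compound 2. Nothing on hand speaks to why these compounds read alike.

As far as these compounds go, whether this position accepts anything other than chloro or hydrogen stays open, since a methoxy, an amine, a carboxylic acid or a longer chain on the same aromatic carbon could read quite differently. Also open is whether any change at this position gives a step beyond the scatter, as the numbers shown lie close together at one concentration and say nothing of potency.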